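Swapping the tetrazolylethyl tail for a carboxycyclopropyl group

The compounds below may be only part of what the source reports. "The series", "measured", "known", "first", "only" and "open" are said of these compounds alone.

Compound 1, `COc1cc(OC(F)(F)F)cc(-c2ccc3c(c2)CC[C@H](CCc2nnn[nH]2)O3)c1F`: in a functional assay on HEK293 cells for agonist activity at Free fatty acid receptor 1 (Homo sapiens), read by HTRF and inositol phosphate accumulation, with a stated time of 60 min (a lower number here means that less compound is needed, a higher number that more compound is needed for the effect), compound 1 gives > 10000 nM, a limit of the assay.
Compound 2, `Fc1ccc(OC(F)(F)F)cc1-c1ccc2c(c1)CC[C@H](CCc1nnn[nH]1)O2`: in this assay compound 2 gives > 10000 nM, a limit of the assay.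
Compound 3, `COc1cc(OC2CCC2)nc(-c2ccc3c(c2)CC[C@H]([C@@H]2C[C@H]2C(=O)O)O3)c1F`: in this assay compound 3 gives > 10000 nM, a limit of the assay.

Compound 2 therefore stands only at a limit, and so do the other two measured compounds: the limit of > 10000 nM in this assay, at which 3 of the 3 values shown sit. Within the data shown here, the one single-point step among them, a step that the two limits leave unreadable from compound 1 to compound 2, cannot be read, since both ends are limits.

Compound 4, `O=C(O)[C@@H]1C[C@H]1[C@H]1CCc2cc(-c3cc(OC(F)(F)F)ccc3F)ccc2O1`, differs from compound 2 in one place: 2-carboxycyclopropyl in place of 2-(1H-tetrazol-5-yl)ethyl on a saturated ring carbon. Among the measured compounds shown here, compound 3 already carries the entering 2-carboxycyclopropyl group on the shared core, attached to a different aromatic substituent, and gives a limit; no measured step bears directly on the change from compound 2 to compound 4. With every measured value at the limit, no direction or size beyond the scatter can be drawn from the numbers. Compound 4 is expected to give about 6000 nM in this assay, within 600 nM to 30000 nM, which amounts to an estimated step of an at least 1.6-fold lower number from compound 2 to compound 4 (0.22 log units; that floor lies within the scatter).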

Compound 4, half-maximal effective concentration: > 10000 nM
Compound 4: only a limit was reported; the forecaster's own chance of this, stated with the estimate: 55%; middle value at least 1.6-fold (0.22 log units) from the limit.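

Compound 4, like compound 2, gives only a limit, so the step between these two compounds cannot be read: the limit of > 10000 nM in this assay, at which 4 of the 4 values shown sit.

The compounds shown leave open how the 2-carboxycyclopropyl and 2-(1H-tetrazol-5-yl)ethyl groups compare on the shared core, and which structural change would give a measurable value.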